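The compounds below may be only part of what the source reports. "The series", "measured", "known", "first", "only" and "open" are said of these compounds alone.

Compound 3 `C=CC(=O)Nc1cccc(NC(=O)CSc2nc(Nc3ccc(Cl)cc3)c3ccccc3n2)c1` gives 10300 nM in a functional assay on MDA-MB-231 cells (Homo sapiens) for inhibition, read by MTT assay, with a stated time of 72 h (a higher number here means a weaker inhibitor, a lower number a stronger inhibitor), the smallest of the three numbers, though that standing means little: compound 1 `C=CC(=O)Nc1cccc(NC(=O)CSc2nc(Nc3ccccc3F)c3ccccc3n2)c1` with 18700 nM and compound 2 `C=CC(=O)Nc1cccc(NC(=O)CSc2nc(Nc3ccccc3C)c3ccccc3n2)c1` with 20400 nM both sit within the scatter of it, as the steps of a 1.8-fold lower number from compound 1 to compound 3 (0.26 log units; within the scatter) and a 2.0-fold lower number from compound 2 to compound 3 (0.30 log units; within the scatter) show, and a 1.1-fold higher number from compound 1 to compound 2 (0.04 log units; within the scatter) is likewise within it. Compound 4 `C=CC(=O)Nc1cccc(NC(=O)CSc2nc(Nc3ccc(Cl)c(Cl)c3)c3ccccc3n2)c1` differs from compound 3 by chloro in place of hydrogen on an aromatic carbon. For the measured compounds named here, no measured step adds a second group to this ring; every recorded step swaps one substituted phenyl for another, and none left the scatter. A step beyond the scatter in this assay is therefore not expected. Compound 4 is estimated at 9000 nM, with a range from 3500 nM to 25000 nM. The expected step is a 1.1-fold lower number from compound 3 to compound 4 (0.06 log units; within the scatter).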

Compound 4, half-maximal inhibitory concentration: 17700 nM
Estimate against measurement, compound 4: 2.0-fold (0.29 log units) below; the measured number falls inside the stated range.
By their numbers in this assay, from the lowest: compounds 3, 4, 1 and 2 (each within the scatter of the next).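

In this assay, chloro in place of hydrogen on the ring of compound 3 gives a 1.7-fold higher number from compound 3 to compound 4 (0.24 log units; within the scatter), so the first second substituent on this ring, ortho to a chloro group, stays within the scatter. The 3,4-dichlorophenyl group also stays within it against 2-methylphenyl, with a 1.2-fold lower number from compound 2 to compound 4 (0.06 log units; within the scatter), and against 2-fluorophenyl, with a 1.1-fold lower number from compound 1 to compound 4 (0.02 log units; within the scatter), so one substituent and two are not told apart here. Nothing measured on these compounds offers an explanation for this.

As far as these compounds go, whether an amine, a carboxylic acid or a methoxy group on this ring would leave the scatter remains open. So does whether a larger ring substituent would.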